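The source may hold more compounds than are shown below. What is called first, only, known or untested is meant among the compounds shown, and "the series" means these compounds.

The shared core is carried by compound 1 `CCSc1n[nH]c(-n2[se]c3ccccc3c2=O)n1`, compound 2 `Cc1ccc(CSc2n[nH]c(-n3[se]c4ccccc4c3=O)n2)cc1`, compound 3 `O=c1c2ccccc2[se]n1-c1nc(SCc2ccc(F)cc2)n[nH]1` and the as yet unmeasured compound 4 `CCCCCSc1n[nH]c(-n2[se]c3ccccc3c2=O)n1`. In a functional assay on HeLa cells (Homo sapiens) for antiproliferative activity, read by CCK-8 assay, with a stated time of 48 h (on this read-out lower numbers stand for stronger inhibition and higher numbers for weaker inhibition), compound 1 gives 14100 nM, and in this assay compound 2 gives 34800 nM. For compound 3 the this assay result is a limit of the assay, > 50000 nM. Compound 1 thus stands lowest of the two numbers recorded; the nearest is compound 2, with a 2.5-fold higher number from compound 1 to compound 2 (0.39 log units; beyond the scatter). The step of an at least 3.5-fold higher number from compound 1 to compound 3 (0.54 log units; beyond the scatter) runs the same way, reaching (the limit of > 50000 nM in this assay, at which 1 of the 3 values shown sits). Between compound 2 and compound 3 there is an at least 1.4-fold higher number from compound 2 to compound 3 (0.15 log units; that floor lies within the scatter).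

Compound 4 differs from compound 1 by propyl in place of hydrogen on a saturated chain carbon, two bonds along the chain from a sulfur. Both measured steps away from compound 1 replaced the methyl on the chain by an aryl group and gave higher numbers; compound 4 lengthens the chain instead, so neither step bears on it directly, and no aliphatic extension has yet been measured in this series. A modest rise in the number, or none beyond the scatter, is expected, and the estimate for compound 4 amounts to a 1.4-fold higher number from compound 1 to compound 4 (0.15 log units; within the scatter). Compound 4 is accordingly expected to give 20000 nM in this assay, within a range from 8000 nM to 50000 nM.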

Compound 4, half-maximal inhibitory concentration: 30300 nM
For compound 4 the middle estimate is 1.5-fold (0.18 log units) below the measured one; low and high end bracket the measured number.
By their numbers in this assay, from the lowest: compound 1; then compounds 4 and 2 (each within the scatter of the next). At a limit, above all of these: compound 3.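

Extending the chain from ethylsulfanyl to pentylsulfanyl gives the first aliphatic change at this position, and in this assay it also raises the number: a 2.1-fold higher number from compound 1 to compound 4 (0.33 log units; beyond the scatter). An aryl group is thus not needed for a rise here, and among the compounds shown, every replacement of the methyl on the chain gives a higher number, with none going against this, so the short ethylsulfanyl chain of compound 1 keeps the lowest value. The butyl and 4-methylphenyl groups on the saturated chain carbon bound to a sulfur are not told apart, with a 1.1-fold lower number from compound 2 to compound 4 (0.06 log units; within the scatter). Compound 3 stands at a limit of the assay, > 50000 nM. Butyl in place of 4-fluorophenyl gives an at least 1.6-fold lower number from compound 3 to compound 4 (0.21 log units; that floor lies within the scatter), a floor that leaves the true size of this step open.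

Nothing shown here accounts for the higher number with the longer chain. Going by these compounds, with only the ethylsulfanyl and pentylsulfanyl chains in hand, it remains open how the number runs with a methylsulfanyl or propylsulfanyl chain, and whether a chain ending in an amine or a carboxylic acid would bring it down.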